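Stability after replacing the 5-methoxypyrazin-2-yl group

The compounds below may be only part of what the source reports. "The series", "measured", "known", "first", "only" and "open" are said of these compounds alone.

For the measured compounds named here, in an ADME assay on microsomes from liver (Rattus norvegicus, strain Crj;CD(SD)) for metabolic stability, read by LC-MS, using NADPH, with a stated time of 30 min, tested at 0.1 uM (on this read-out higher numbers stand for a more stable compound and lower numbers for a less stable compound), compound 3 (`COc1cnc(C(=O)Nc2ccc(F)c([C@]3(C)C=C(CF)OC(N)=N3)c2)cn1`) gives 13%, the lowest of the three numbers measured so far. Compound 1 (`Cc1cc(C#N)cnc1C(=O)Nc1ccc(F)c([C@]2(C)C=C(CF)OC(N)=N2)c1`) gives 34%, and compound 2 (`C[C@@]1(c2cc(NC(=O)c3coc(C(F)F)n3)ccc2F)C=C(CF)OC(N)=N1`) gives 57%. Compound 4 (`C[C@@]1(c2cc(NC(=O)c3coc(CF)n3)ccc2F)C=C(CF)OC(N)=N1`) is still unmeasured. It carries 2-(fluoromethyl)-1,3-oxazol-4-yl in place of 5-methoxypyrazin-2-yl on a carbonyl carbon.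

Compound 2 is the closest guide, as it holds 2-(difluoromethyl)-1,3-oxazol-4-yl in that place. The exchange of that group for 5-methoxypyrazin-2-yl gave a number 44 percentage points lower from compound 2 to compound 3 (beyond the scatter). Starting from 5-cyano-3-methylpyridin-2-yl, the two other measured exchanges gave a number 23 percentage points higher from compound 1 to compound 2 (beyond the scatter) and a number 21 percentage points lower from compound 1 to compound 3 (beyond the scatter), so they run in opposite directions. Going by the values given here, no measured pair shows what fluoromethyl does compared with difluoromethyl, so the full reverse of the largest step is not assumed. A clear rise is nevertheless expected, with an estimated a number 32 percentage points higher from compound 3 to compound 4 (beyond the scatter). For compound 4 the estimated value is 45%, with an expected range from 25% to 65%.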

Compound 4, percent of the compound remaining: 39%
Compound 4: the middle estimate sits 6 percentage points above what was measured; the measured number falls inside the stated range.
By their numbers in this assay, from the lowest: compound 3; then compounds 1 and 4 (each within the scatter of the next); then compound 2.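

In this assay, for the compounds shown here, the change of fluoro to hydrogen on the saturated chain carbon gives the first direct reading of how many fluorines that chain carries (a number 18 percentage points lower from compound 2 to compound 4 (beyond the scatter)). The rise over 5-methoxypyrazin-2-yl survives this loss of a fluorine (a number 26 percentage points higher from compound 3 to compound 4 (beyond the scatter)), so it does not require the difluoromethyl group. Against 5-cyano-3-methylpyridin-2-yl, however, 2-(fluoromethyl)-1,3-oxazol-4-yl keeps none of the clear margin that compound 2 held (a number 5 percentage points higher from compound 1 to compound 4 (within the scatter)).

As far as these compounds go, what 2-(trifluoromethyl)-1,3-oxazol-4-yl or 2-methyl-1,3-oxazol-4-yl would give on the same carbonyl carbon remains open, so the trend rests on a single pair. No evidence at hand explains why the fluorine count on this chain shifts the stability.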